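This account rests on a few compounds, and the source may have more. Where it says the series, first, only, none or still open, it means among the compounds named here.

Among the compounds with values here, compound 3 `CCCCc1ccc(CN(C)S(=O)(=O)c2ccccc2)c(=O)n1Cc1ccc(-c2ccccc2-c2nn[nH]n2)cc1` gives 2 nM in a functional assay (aorta) for antagonist activity, with Oryctolagus cuniculus as the target (a lower number here means a stronger inhibitor, a higher number a weaker inhibitor), the second highest of the three numbers known so far. Nearest to it is compound 1 `CCCCc1ccc(CN(Cc2ccccc2)C(C)=O)c(=O)n1Cc1ccc(-c2ccccc2-c2nn[nH]n2)cc1` with 1 nM; the step of a 2.0-fold higher number from compound 1 to compound 3 (0.30 log units; within the scatter) lies within the scatter. Furthest from it is compound 2 `CCCCc1ccc(CNS(=O)(=O)c2ccc(C)cc2)c(=O)n1Cc1ccc(-c2ccccc2-c2nn[nH]n2)cc1` with 9 nM; the step of a 4.5-fold lower number from compound 2 to compound 3 (0.65 log units; beyond the scatter) lies beyond the scatter. Compound 4 `CCCCc1cccc(=O)n1Cc1ccc(-c2ccccc2-c2nn[nH]n2)cc1` has not yet been measured in this assay. It differs from compound 3 by hydrogen in place of (methyl(phenylsulfonyl)amino)methyl on an aromatic carbon. Within the data shown here, no measured step removes the whole substituent at that position; the steps of a 9.0-fold higher number from compound 1 to compound 2 (0.95 log units; beyond the scatter) and a 4.5-fold lower number from compound 2 to compound 3 (0.65 log units; beyond the scatter) only exchange one group for another there, yet both are modest and beyond the scatter, so the position is responsive to what it carries. Because the exchanges a 9.0-fold higher number from compound 1 to compound 2 (0.95 log units; beyond the scatter) and a 4.5-fold lower number from compound 2 to compound 3 (0.65 log units; beyond the scatter) already shift the number, stripping the group entirely is expected to shift it further upward. Compound 4 is therefore expected to give about 60 nM, within a range from 10 nM to 400 nM. That expectation corresponds to an estimated step of a 30-fold higher number from compound 3 to compound 4 (1.48 log units; beyond the scatter).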

Compound 4, half-maximal inhibitory concentration: 4 nM
Estimate against measurement, compound 4: 15-fold (1.18 log units) above; measured number outside the range, below it.
By their numbers in this assay, from the lowest: compounds 1, 3 and 4 (each within the scatter of the next, the first and the last beyond it); then compound 2.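

In this assay, the entire (methyl(phenylsulfonyl)amino)methyl group, with its 12 heavy atoms, gives way to hydrogen in a 2.0-fold higher number from compound 3 to compound 4 (0.30 log units; within the scatter), so the core of compound 4 reaches 4 nM with no substituent at this place. The other two comparisons point in opposite directions, a 2.3-fold lower number from compound 2 to compound 4 (0.35 log units; beyond the scatter) and a 4.0-fold higher number from compound 1 to compound 4 (0.60 log units; beyond the scatter), which places hydrogen between the (((4-methylphenyl)sulfonyl)amino)methyl and (acetyl(benzyl)amino)methyl groups. Nothing in the data shown explains these differences.

Going by these compounds, it remains open whether a small group at this place, such as a methyl, a primary amine or a carboxylic acid, would fall near hydrogen or move the number further. The compounds shown also do not separate the two structural differences between the ((4-methylphenyl)sulfonyl)amino and methyl(phenylsulfonyl)amino groups.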